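Series notes: sulfonyl to carbonyl at the ring nitrogen

The source may report more compounds than this note shows. Statements on the series, on what has been measured and on what is new or still open speak of the compounds shown alone.

Measured in a functional assay on MCF7 cells (Homo sapiens) for inhibition, read by MTT assay, with a stated time of 48 h; a lower number here means a stronger inhibitor, a higher number a weaker inhibitor:
compound 1 `COc1ccc(CN(c2cc(OC)c(OC)c(OC)c2)S(=O)(=O)c2ccc(C)cc2)cc1` gives 10100 nM
compound 2 `COc1cc(N(Cc2ccc(Cl)cc2)S(=O)(=O)c2ccc(C)cc2)cc(OC)c1OC` gives 18600 nM
compound 3 `COc1cc(N(Cc2nc3ccccc3[nH]2)S(=O)(=O)c2ccc(C)cc2)cc(OC)c1OC` gives 5400 nM

Compound 3 has the lowest of the three numbers in this assay; the step of a 1.9-fold lower number from compound 1 to compound 3 (0.27 log units; within the scatter) lies within the scatter, while a 3.4-fold lower number from compound 2 to compound 3 (0.54 log units; beyond the scatter) lies beyond it. Compound 4 `COc1cc(N(Cc2nc3ccccc3[nH]2)C(=O)c2cccc(Cl)c2)cc(OC)c1OC` differs from compound 3 by (3-chlorophenyl)carbonyl in place of (4-methylphenyl)sulfonyl on a nitrogen on an aromatic ring. Within the data shown here, every measured step, including a 1.8-fold higher number from compound 1 to compound 2 (0.27 log units; within the scatter), changed only the group on the saturated chain carbon; none touched the group on the ring nitrogen, so no measured step bears on this change, and the range must stay wide. The step expected for compound 4 is a 1.1-fold higher number from compound 3 to compound 4 (0.05 log units; within the scatter), none beyond the scatter. Compound 4 is estimated at 6000 nM in this assay, between 1500 nM and 25000 nM.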

Compound 4, half-maximal inhibitory concentration: 34900 nM
Compound 4: the middle estimate sits 5.8-fold (0.76 log units) below what was measured; the whole stated range lies below it.
By their numbers in this assay, from the lowest: compounds 3, 1, 2 and 4 (each within the scatter of the next, the first and the last beyond it).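

In this assay, among these compounds, the group on a nitrogen on an aromatic ring proves to matter: (3-chlorophenyl)carbonyl in place of (4-methylphenyl)sulfonyl gives a 6.5-fold higher number from compound 3 to compound 4 (0.81 log units; beyond the scatter), the first measured step at this position. The step changes the sulfonyl to a carbonyl and the aromatic substituent together, so the share of each cannot be separated. Nothing available explains the size of this step.

Open, from the compounds shown here alone, is whether (4-methylphenyl)carbonyl or (3-chlorophenyl)sulfonyl would track compound 3 or compound 4, which would separate the two changes.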